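The source may hold more compounds than are shown below. What is called first, only, known or untested is meant among the compounds shown, and "the series" means these compounds.

Values so far in a functional assay on A549 cells (Homo sapiens) for cytotoxicity, read by MTT assay, with a stated time of 72 h (a higher number here means a weaker inhibitor, a lower number a stronger inhibitor), are
- compound 1 `O=C(N/N=C/c1ccc(F)cc1)Nc1cc2c(Nc3ccc(F)c(Cl)c3)ncnc2cc1O[C@H]1CCOC1` gives 35100 nM
- compound 2 `O=C(N/N=C/c1ccc([N+](=O)[O-])cc1)Nc1cc2c(Nc3ccc(F)c(Cl)c3)ncnc2cc1O[C@H]1CCOC1` gives 31200 nM
- compound 3 `O=C(N/N=C/c1ccc(F)cc1Cl)Nc1cc2c(Nc3ccc(F)c(Cl)c3)ncnc2cc1O[C@H]1CCOC1` gives 27200 nM

Compound 3 cannot be told apart from the other two. The steps of a 1.3-fold lower number from compound 1 to compound 3 (0.11 log units; within the scatter) and a 1.1-fold lower number from compound 2 to compound 3 (0.06 log units; within the scatter) stay within the scatter, and so does a 1.1-fold lower number from compound 1 to compound 2 (0.05 log units; within the scatter) as well.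

Next is compound 4 `COc1cc(/C=N/NC(=O)Nc2cc3c(Nc4ccc(F)c(Cl)c4)ncnc3cc2O[C@H]2CCOC2)cc(OC)c1OC`, with 3,4,5-trimethoxyphenyl in place of 2-chloro-4-fluorophenyl on a carbon with a double bond to nitrogen as the change: 3,4,5-trimethoxyphenyl in place of 2-chloro-4-fluorophenyl on a carbon with a double bond to nitrogen. Among the compounds with values here, all three measured changes on this aryl group left the number flat, but no measured compound carries a 3,4,5-trimethoxyphenyl group, so the range stays wide. No shift beyond the scatter is expected, and the expected move is a 1.1-fold higher number from compound 3 to compound 4 (0.04 log units; within the scatter) in size. Compound 4 is estimated at 30000 nM within a range from 15000 nM to 60000 nM in this assay again.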

Compound 4, half-maximal inhibitory concentration: 26400 nM
Compound 4: the middle estimate sits 1.1-fold (0.06 log units) above what was measured; low and high end bracket the measured number.
By their numbers in this assay, from the lowest: compounds 4, 3, 2 and 1 (each within the scatter of the next).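

In this assay, the steps to 3,4,5-trimethoxyphenyl, an aryl group with more heavy atoms that carries hydrogen-bond acceptors, all stay within the scatter (a 1.0-fold lower number from compound 3 to compound 4 (0.01 log units; within the scatter)) and (a 1.2-fold lower number from compound 2 to compound 4 (0.07 log units; within the scatter)) and (a 1.3-fold lower number from compound 1 to compound 4 (0.12 log units; within the scatter)). The position on the carbon with a double bond to nitrogen therefore accepts oxygen-bearing substituents as well as halogen and nitro ones, with no separation among the four compounds. No evidence bears on why the number stays flat. Still open, from the compounds shown here alone, is whether an aryl group bearing a carboxylic acid or an amine, or a non-aromatic group such as cyclohexyl, would move the number beyond the scatter.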